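This account rests on a few compounds, and the source may have more. Where it says the series, first, only, none or still open, it means among the compounds named here.

Three compounds built on one shared core were tested in a functional assay on CHO cells with adenosine receptor A1 (Homo sapiens) as the target, read by cAMP accumulation and immunoassay, with a stated time of 6 min, tested at 0.1 uM; on this read-out lower numbers stand for a stronger effect and higher numbers for a weaker effect at the one concentration tested. Compound 1 `COc1ccc(N2CCN(Cc3csc(N)c3C(=O)c3ccc(Cl)cc3)CC2)cc1` gives 0% in this assay. Compound 2 `Nc1scc(CN2CCN(c3ccc(OC(F)(F)F)cc3)CC2)c1C(=O)c1ccc(Cl)cc1` gives -13% in this assay, and compound 3 `Nc1scc(CN2CCN(c3ccccc3Cl)CC2)c1C(=O)c1ccc(Cl)cc1` gives 2%. Among the three numbers, compound 3 stands at the top as written, but its distance from compound 1 lies within the scatter (a number 2 percentage points higher from compound 1 to compound 3 (within the scatter)), so the two cannot really be told apart; only its distance from compound 2 is beyond the scatter (a number 15 percentage points higher from compound 2 to compound 3 (beyond the scatter)).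

Compound 4 `Nc1scc(CN2CCN(c3ccc(Cl)c(Cl)c3)CC2)c1C(=O)c1ccc(Cl)cc1` has not yet been measured. It differs from compound 3 in one place: 3,4-dichlorophenyl in place of 2-chlorophenyl on an amine nitrogen in a ring. Among the compounds with values here, two measured steps bear on this, since both exchange the group on the same ring nitrogen: a number 2 percentage points higher from compound 1 to compound 3 (within the scatter) and a number 15 percentage points higher from compound 2 to compound 3 (beyond the scatter). The first is within the scatter and the second is modest, so exchanging this group has so far shifted the read-out only a little, with no consistent direction. A step of similar or smaller size is therefore expected here. Compound 4 is estimated at 0%, with a range from -15% to 15%. This corresponds to an expected step of a number 2 percentage points lower from compound 3 to compound 4 (within the scatter).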

Compound 4, a percentage reported as activity, at one concentration (the size of the read-out at that concentration, not a potency): -13%
Compound 4: the middle estimate sits 13 percentage points above what was measured; measured number inside the range.
By their numbers in this assay, from the lowest: compounds 2 and 4 (each within the scatter of the next); then compounds 1 and 3 (each within the scatter of the next).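

In this assay, within the data shown here, 3,4-dichlorophenyl on the ring nitrogen gives a number 15 percentage points lower from compound 3 to compound 4 (beyond the scatter) and a number 13 percentage points lower from compound 1 to compound 4 (beyond the scatter), so 4-(trifluoromethoxy)phenyl is no longer the only group at this position that sets a compound apart from compounds 1 and 3. Two quite different groups now read alike, with no change at the digits printed from compound 2 to compound 4 (within the scatter), and the series falls into two pairs: compounds 2 and 4 on the lower side, compounds 1 and 3 on the higher side. Neither chlorine on the phenyl ring nor a group at the 4 position is enough on its own, since compound 3 carries 2-chlorophenyl and compound 1 carries 4-methoxyphenyl, and both stay in the higher pair, while nothing available explains why these groups sort this way.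

The compounds shown leave open which chlorine of the 3,4-dichlorophenyl group matters, a question that 3-chlorophenyl and 4-chlorophenyl on the same nitrogen would address. They also leave open where plain phenyl would fall, and whether these modest steps at one concentration would carry over to full potency.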